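The source may hold more compounds than are shown below. What is called first, only, known or untested is meant among the compounds shown, and "the series" means these compounds.

Compound 1, `CCCCC(O)c1cccc(NC(=O)NCCCCl)c1`, is one of two measured members of a small series of aryl ureas sharing a core. Among the measured compounds shown here, in a functional assay on M21 cells (Homo sapiens) for antiproliferative activity, with a stated time of 48 h (on this read-out lower numbers stand for stronger inhibition and higher numbers for weaker inhibition), compound 1 gives 35000 nM, the lowest of the two numbers recorded, though its only neighbour sits close: compound 2, `CCCCC(OC)c1cccc(NC(=O)NCCCCl)c1`, gives 51000 nM, and a 1.5-fold higher number from compound 1 to compound 2 (0.16 log units; within the scatter). That single measured step, methyl in place of hydrogen on an oxygen on a saturated carbon, is the whole of what the series says so far.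

Compound 3, `CCCCC(O)c1cccc(NC(=O)NC(=O)CCl)c1`, is not yet measured. It differs from compound 1 in one place: (chloromethyl)carbonyl in place of 3-chloropropyl on an amide-type nitrogen. For the measured compounds named here, no measured step touches the urea side of the molecule; the step from compound 1 to compound 2 concerns the other end and lay within the scatter, so it offers no guide to the direction or size of this change. With nothing to anchor a shift, the number for compound 3 is expected to stay near that of compound 1, with a wide band on either side, so that a 1.2-fold lower number from compound 1 to compound 3 (0.07 log units; within the scatter) is expected. The estimate for compound 3 in this assay is 30000 nM, expected to fall between 5000 nM and 150000 nM.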

Compound 3, half-maximal inhibitory concentration: 4600 nM
Estimate against measurement, compound 3: 6.5-fold (0.81 log units) above, outside the stated range (below it).
By their numbers in this assay, from the lowest: compound 3; then compounds 1 and 2 (each within the scatter of the next).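

Among the compounds shown here, the urea side of the molecule proves responsive in this assay: placing (chloromethyl)carbonyl instead of 3-chloropropyl on the amide-type nitrogen gives a 7.6-fold lower number from compound 1 to compound 3 (0.88 log units; beyond the scatter) and so moves the number far more than the only earlier step, which lay at the other end of the molecule and stayed within the scatter. The entering and leaving groups have the same number of heavy atoms, and the change adds a double bond outside aromatic rings and a hydrogen-bond acceptor, so the step goes with the kind of group at this position and not with its count of heavy atoms. No measurement at hand accounts for the shift.

From the compounds shown here alone, it remains open which part of the new group goes with the lower number: a 3-chloropropanoyl group, an acetyl group without the chlorine, or a 2-chloroethyl group on the same nitrogen would separate the carbonyl from the chlorine and the chain. Going by these compounds, it is equally open whether a methyl ether at the other end of the molecule would behave alongside (chloromethyl)carbonyl as it does alongside 3-chloropropyl.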